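The source may report more compounds than this note shows. Statements on the series, on what has been measured and on what is new or still open speak of the compounds shown alone.

Series notes. Within the data shown here, compound 1 `O=C(CSc1nnc(-c2ccncc2)o1)N/N=C/c1ccc(Cl)cc1` gives 15700 nM in a functional assay on HepG2 cells (Homo sapiens) for cytotoxicity, read by MTT assay, with a stated time of 48 h (a lower number here means a stronger inhibitor, a higher number a weaker inhibitor), the highest of the three numbers measured so far. Compound 2 `O=C(CSc1nnc(-c2ccncc2)o1)N/N=C/c1ccc(O)cc1` gives 5510 nM and compound 3 `O=C(CSc1nnc(-c2ccncc2)o1)N/N=C/c1cc(Br)cc(Br)c1O` gives 6540 nM. Compound 4 `O=C(CSc1nnc(-c2ccncc2)o1)N/N=C/c1ccc(O)c(O)c1` is not yet measured; it differs from compound 1 as follows: 3,4-dihydroxyphenyl in place of 4-chlorophenyl on a carbon with a double bond to nitrogen. Among the measured compounds shown here, two measured steps bear on this change. Hydroxy in place of chloro gave a 2.8-fold lower number from compound 1 to compound 2 (0.45 log units; beyond the scatter), and 3,5-dibromo-2-hydroxyphenyl in place of 4-chlorophenyl gave a 2.4-fold lower number from compound 1 to compound 3 (0.38 log units; beyond the scatter); between those two products there was a 1.2-fold higher number from compound 2 to compound 3 (0.07 log units; within the scatter). A step of similar size and direction is therefore expected for compound 4, roughly a 3.1-fold lower number from compound 1 to compound 4 (0.50 log units; beyond the scatter), because of a 2.8-fold lower number from compound 1 to compound 2 (0.45 log units; beyond the scatter). Compound 4 is estimated at 5000 nM, within 2200 nM to 11500 nM.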

Compound 4, half-maximal inhibitory concentration: 760 nM
Compound 4: the middle estimate sits 6.6-fold (0.82 log units) above what was measured, and the stated range ends above it.
By their numbers in this assay, from the lowest: compound 4; then compounds 2 and 3 (each within the scatter of the next); then compound 1.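

In this assay, the 3,4-dihydroxyphenyl group on a carbon with a double bond to nitrogen gives a far larger gain than any earlier change, a 21-fold lower number from compound 1 to compound 4 (1.32 log units; beyond the scatter). Hydroxy in place of hydrogen on an aromatic carbon gives a 7.3-fold lower number from compound 2 to compound 4 (0.86 log units; beyond the scatter), so a further hydroxy still moves the number, and the replacement of 3,5-dibromo-2-hydroxyphenyl gives an 8.6-fold lower number from compound 3 to compound 4 (0.93 log units; beyond the scatter), opening a gap that the earlier hydroxy-bearing compounds did not show. No measurement shown accounts for this gain. As far as these compounds go, whether methoxy or amino in place of either hydroxy would hold the low number stays open.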